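The compounds below may be only part of what the source reports. "The series", "measured", "known", "first", "only" and "open" are said of these compounds alone.

In a functional assay on KBVIN cells (Homo sapiens) for antiproliferative activity, read by sulforhodamine B assay, with a stated time of 3 days (a lower number here means a stronger inhibitor of growth, a higher number a weaker inhibitor of growth), compound 1 `O=C(Nc1nccs1)c1cccc(Nc2ncc(F)c(Nc3ccc(F)cc3)n2)c1` reads > 10000 nM, which is a limit of the assay and not a number. Compound 2 `O=C(Nc1cccc(Nc2ncc(F)c(Nc3ccc(F)cc3)n2)c1)c1cnccn1`, which carries a different group on the same aromatic carbon, gives 20100 nM. Compound 3 `COCC(=O)Nc1cccc(Nc2ncc(F)c(Nc3ccc(F)cc3)n2)c1`, another such relative, gives 3940 nM.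

Compound 4 `COc1cc(NC(=O)c2cccc(Nc3ncc(F)c(Nc4ccc(F)cc4)n3)c2)cc(OC)c1` has not yet been measured. It keeps the carbonyl and amide-type nitrogen of compound 1 and changes the ring on that nitrogen: 3,5-dimethoxyphenyl in place of 1,3-thiazol-2-yl on an amide-type nitrogen. In words, 3,5-dimethoxyphenyl stands in place of 1,3-thiazol-2-yl.

Within the data shown here, no measured step makes this same swap, so the guidance is indirect. The nearest steps replace the whole group on the aromatic carbon. One is a step that the limit leaves unreadable from compound 1 to compound 2. Another is an at least 2.5-fold lower number from compound 1 to compound 3 (0.40 log units; beyond the scatter). The third is a 5.1-fold lower number from compound 2 to compound 3 (0.71 log units; beyond the scatter). These steps show that changes in this part of the molecule can move the number beyond the scatter, but none of them shows what a new ring on the amide-type nitrogen will do.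

With compound 1 at > 10000 nM, a weak result remains the most likely outcome, and the assay may again report only a limit. The expected change is small, slightly toward a lower number: an at least 1.2-fold lower number from compound 1 to compound 4 (0.09 log units; that floor lies within the scatter). For compound 4 the estimated value is 8000 nM, within an expected range of 2500 nM to 25000 nM.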

Compound 4, concentration for 50% growth inhibition: 12700 nM
Estimate against measurement, compound 4: 1.6-fold (0.20 log units) below, within the range that was stated.
By their numbers in this assay, from the lowest: compound 3; then compounds 4 and 2 (each within the scatter of the next).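

Compound 1 has only a limit and not a number, so no size can be given for the step from compound 1 to compound 4 in this assay: the limit of > 10000 nM in this assay, at which 1 of the 4 values shown sits. The compounds shown leave open whether 3,5-dimethoxyphenyl in place of 1,3-thiazol-2-yl on an amide-type nitrogen moves the number at all, and in which direction.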